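A Carboxy Group Enters the Chain of Compound 1

A few compounds are considered here, and "the series" means these few. Any claim that something is new, unique, unknown or untested is made for them only; others in the source may bear on it.

Compound 1, `CCCCn1cc(C(=O)C(=O)Nc2ccc(OC)nc2)c2ccccc21`: 18 nM
Compound 2, `COc1ccc(NC(=O)C(=O)c2cn(C(C)C)c3ccccc23)cc1`: 181 nM
Compound 3, `COc1cc(NC(=O)C(=O)c2cn(C(C)C)c3ccccc23)ccn1`: 1750 nM

In a functional assay on FaDu cells (Homo sapiens) for cytotoxicity, read by MTT assay, with a stated time of 72 h (a higher number here means that more compound is tolerated, a lower number that less compound is tolerated), compound 1 stands lowest of the three measured compounds, clearly below compound 2 and further still below compound 3. Compound 4, `COc1ccc(NC(=O)C(=O)c2cn(CCC(=O)O)c3ccccc23)cn1`, has not been measured; it differs from compound 1 by carboxy in place of ethyl on a saturated chain carbon, two bonds along the chain from an aromatic nitrogen. Going by the values given here, the only measured step, a 9.7-fold higher number from compound 2 to compound 3 (0.99 log units; beyond the scatter), concerns the group on the amide nitrogen and not the chain, so it does not bear on this change. Among the compounds with values here, compounds 2 and 3 carry an isopropyl in place of the chain, and no measured pair isolates a change at the chain. The step from compound 1 to compound 4 is therefore uncertain, and a rise in the number is expected, as a 22-fold higher number from compound 1 to compound 4 (1.35 log units; beyond the scatter). The estimate for compound 4 is 400 nM, with a range from 60 nM to 4000 nM.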

Compound 4, concentration lethal to 50% of the cells: > 10000 nM
Compound 4: no number, only a limit (the forecaster's own chance of this, stated with the estimate: 10%); at least 25-fold (1.39 log units) between middle value and limit.
By their numbers in this assay, from the lowest: compound 1; then compound 2; then compound 3. At a limit, above all of these: compound 4.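

The chain on the aromatic nitrogen is not a free place for change: in this assay, carboxy in place of ethyl gives an at least 550-fold higher number from compound 1 to compound 4 (2.74 log units; beyond the scatter). Compounds 2 and 3 could not show this, as they carry isopropyl there. For compound 4, > 10000 nM is a limit of the assay and not a number, so the step has no known upper end.

A methyl ester, an amine or a longer chain ending in carboxy at this place could show whether the carboxy group itself matters, or only any change from butyl. On these data alone, how far the number rises with each remains open.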